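Compound 3 to compound 4: swapping the aromatic ring

The source may report more compounds than this note shows. Statements on the series, on what has been measured and on what is new or still open speak of the compounds shown alone.

Within the data shown here, in a physicochemical assay for solubility, in phosphate buffer, with a stated time of 18 h (on this read-out higher numbers stand for higher solubility and lower numbers for lower solubility), compound 3 (`CC(C)(C)c1nc(-c2ccccn2)c2c(N)c(C#N)c(N)nc2n1`) gives 87000 nM, the highest of the three numbers so far. Compound 1 (`CSc1nc(C(C)(C)C)nc2nc(N)c(C#N)c(N)c12`) gives 14000 nM, and compound 2 (`CC(C)(C)c1nc(-c2ccccc2)c2c(N)c(C#N)c(N)nc2n1`) gives 4000 nM.

The next compound, compound 4 (`CC(C)(C)c1nc(-c2ccc(C(=O)O)s2)c2c(N)c(C#N)c(N)nc2n1`), carries 5-carboxythiophen-2-yl in place of pyridin-2-yl on an aromatic carbon of the shared core: 5-carboxythiophen-2-yl in place of pyridin-2-yl on an aromatic carbon.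

Among the measured compounds shown here, three measured steps concern this same carbon. Two are modest: a 3.5-fold lower number from compound 1 to compound 2 (0.54 log units; beyond the scatter) with phenyl in place of methylsulfanyl, and a 6.2-fold higher number from compound 1 to compound 3 (0.79 log units; beyond the scatter) with pyridin-2-yl in place of methylsulfanyl. The third is large: a 22-fold higher number from compound 2 to compound 3 (1.34 log units; beyond the scatter) with pyridin-2-yl in place of phenyl. That last step, an exchange of one aromatic ring for another, argues for a wide range on the next exchange. For the measured compounds named here, no measured compound carries a thiophene ring or a carboxy group, so the data do not fix the direction. The expected change is a 2.3-fold higher number from compound 3 to compound 4 (0.36 log units; beyond the scatter), a modest rise that rests on a judgement of the structural change alone. For compound 4 the estimated value in this assay is 200000 nM, with an expected range of 50000 nM to 600000 nM.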

Compound 4, solubility: > 1000000 nM
Compound 4: only a limit was reported; the forecaster's own chance of this, stated with the estimate: 30%; middle value at least 5.0-fold (0.69 log units) from the limit.
By their numbers in this assay, from the lowest: compound 2; then compound 1; then compound 3. At a limit, above all of these: compound 4.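

In this assay compound 4 gives > 1000000 nM, a limit of the assay and not a number, and the only such entry in the series: the limit of > 1000000 nM in this assay, at which 1 of the 4 values shown sits.

Even the smallest new step, an at least 11-fold higher number from compound 3 to compound 4 (1.06 log units; beyond the scatter), starts from the highest of the earlier numbers, and the other two are wider still: an at least 71-fold higher number from compound 1 to compound 4 (1.85 log units; beyond the scatter) and an at least 250-fold higher number from compound 2 to compound 4 (2.39 log units; beyond the scatter). This aromatic carbon of the shared core therefore spans a wider range than the exchange of phenyl for pyridin-2-yl alone had shown, and 5-carboxythiophen-2-yl now stands at the top of the series.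

The change from pyridin-2-yl alters two things at once, the aromatic ring and the carboxy group, so the step cannot be divided between them on these compounds. From the compounds shown here alone, a plain thiophen-2-yl, a carboxyphenyl ring, or a methyl ester or primary amide in place of the carboxylic acid would be needed to separate the two, and how far compound 4 lies beyond its limit also stays open.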